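The compounds below may be only part of what the source reports. "The series", "measured", "known", "first", "only" and "open" are said of these compounds alone.

Compound 1 `Cc1ccc(S(=O)(=O)NC(=O)/C=C/c2ccccc2)cc1`: 13.8 ug/mL
Compound 2 `Cc1ccc(S(=O)(=O)NC(=O)/C=C/c2ccc(Cl)cc2)cc1`: 4.6 ug/mL

Both were tested in a functional assay on B16-F10 cells (Mus musculus) for antiproliferative activity, read by ELISA and MTT assay, with a stated time of 48 h; a lower number here means a stronger inhibitor, a higher number a weaker inhibitor. Compound 2 gives the lowest of the two numbers. Going by the values given here, the one measured step, a 3.0-fold lower number from compound 1 to compound 2 (0.48 log units; beyond the scatter), lies beyond the scatter. Compound 3 `COc1ccc(/C=C/C(=O)NS(=O)(=O)c2ccc(C)cc2)cc1` has not been measured. It differs from compound 2 in one place: methoxy in place of chloro on an aromatic carbon. The only step bearing on this position is a 3.0-fold lower number from compound 1 to compound 2 (0.48 log units; beyond the scatter); whether methoxy behaves like chloro there is not shown. For compound 3 a small step, within the scatter or slightly toward a higher number, is expected: a 1.7-fold higher number from compound 2 to compound 3 (0.24 log units; within the scatter). Compound 3 is therefore estimated at 8 ug/mL, with a range from 3 ug/mL to 20 ug/mL.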

Compound 3, half-maximal inhibitory concentration: 12.2 ug/mL
Beside the measured number, compound 3's estimate is 1.5-fold (0.18 log units) below it; measured number inside the range.
By their numbers in this assay, from the lowest: compound 2; then compounds 3 and 1 (each within the scatter of the next).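

In this assay the lower number seen with chloro does not carry over to methoxy at this position: the change gives a 2.7-fold higher number from compound 2 to compound 3 (0.42 log units; beyond the scatter) and shows that the two groups are not interchangeable here. Methoxy in place of hydrogen gives a 1.1-fold lower number from compound 1 to compound 3 (0.05 log units; within the scatter) and so, of the two groups shown, only chloro separates from the hydrogen of compound 1. Nothing available explains this difference between chloro and methoxy. The compounds shown leave open how other groups at this position, such as fluoro, nitro or an amine, would compare. They also leave open whether chloro would give a similar step elsewhere on the ring.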